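Working notes: fluoro to methoxy on compound 2

A few compounds are considered here, and "the series" means these few. Any claim that something is new, unique, unknown or untested is made for them only; others in the source may bear on it.

- compound 1 `COc1ccccc1/C=C(\C(=O)c1ccc(Cl)cc1)S(=O)(=O)Cc1ccc(Cl)c(Cl)c1` gives 1000 nM
- compound 2 `O=C(/C(=C\c1ccccc1F)S(=O)(=O)c1ccc(Br)cc1)c1ccc(Cl)cc1` gives 25000 nM

Both values come from a functional assay on DU-145 cells (Homo sapiens) for inhibition, read by trypan blue exclusion, with a stated time of 96 h; on this read-out lower numbers stand for stronger inhibition of growth and higher numbers for weaker inhibition of growth. Compound 2 has the higher number of the two, beyond the scatter from compound 1. Compound 3 `COc1ccccc1/C=C(\C(=O)c1ccc(Cl)cc1)S(=O)(=O)c1ccc(Br)cc1` departs from compound 2 in one place: methoxy in place of fluoro on an aromatic carbon, with 2-fluorophenyl becoming 2-methoxyphenyl, ortho to a large group. Among the compounds with values here, no measured step isolates this change. Compound 1 also carries 2-methoxyphenyl, though it differs elsewhere too, and gives 1000 nM, so a lower number beyond the scatter is expected. The expected move is a 5.0-fold lower number from compound 2 to compound 3 (0.70 log units; beyond the scatter). For compound 3 the estimated value is 5000 nM, within 1200 nM to 20000 nM.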

Compound 3, concentration for 50% growth inhibition: 10000 nM
Beside the measured number, compound 3's estimate is 2.0-fold (0.30 log units) below it; low and high end bracket the measured number.
By their numbers in this assay, from the lowest: compound 1; then compound 3; then compound 2.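

In this assay, within the data shown here, the methoxy in place of fluoro, ortho to a large group, gives a 2.5-fold lower number from compound 2 to compound 3 (0.40 log units; beyond the scatter) and is the first isolated reading of this position. With 2-methoxyphenyl held fixed, 4-bromophenyl in place of 3,4-dichlorobenzyl on the sulfonyl sulfur gives a 10-fold higher number from compound 1 to compound 3 (1.00 log units; beyond the scatter) as a larger step than the fluoro to methoxy change. No measured evidence accounts for either step.

Open, going by these compounds, is whether a hydroxyl or an amine at this position would follow methoxy. Also open, on these data alone, is whether the methoxy step holds with 3,4-dichlorobenzyl on the sulfonyl sulfur.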